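Quinolin-6-yl to 1H-indol-6-yl at the weak end

The compounds below may be only part of what the source reports. "The series", "measured", "known", "first", "only" and "open" are said of these compounds alone.

In a functional assay on K562 cells (Homo sapiens) for inhibition, read by trypan blue exclusion, with a stated time of 72 h (on this read-out higher numbers stand for weaker inhibition and lower numbers for stronger inhibition), compound 1 `Cn1c(=O)c(S(=O)(=O)c2ccccc2)cc2cnc(Nc3ccc4ncccc4c3)nc21` stands highest at 100000 nM of the two measured values. Compound 2 `Cn1c(=O)c(S(=O)(=O)c2ccc(F)cc2F)cc2cnc(Nc3ccc4c(c3)CC(=O)N4)nc21` gives 15000 nM as a lower number beyond the scatter, yet it differs from compound 1 in more than one place. Compound 3 `Cn1c(=O)c(S(=O)(=O)c2ccccc2)cc2cnc(Nc3ccc4cc[nH]c4c3)nc21` carries 1H-indol-6-yl in place of quinolin-6-yl on a nitrogen on an aromatic ring and remains unmeasured. Among the measured compounds shown here, no single-change step exists as a guide. A modest expected move towards stronger inhibition, beyond the scatter, is estimated as a 3.3-fold lower number from compound 1 to compound 3 (0.52 log units; beyond the scatter) in this assay for now. Compound 3 is estimated at 30000 nM within an expected range of 5000 nM to 100000 nM in this series.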

Compound 3, half-maximal inhibitory concentration: 10000 nM
For compound 3 the middle estimate is 3.0-fold (0.48 log units) above the measured one, within the range that was stated.
By their numbers in this assay, from the lowest: compounds 3 and 2 (each within the scatter of the next); then compound 1.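

Replacing quinolin-6-yl with 1H-indol-6-yl on a nitrogen on an aromatic ring gives, in this assay, a 10-fold lower number from compound 1 to compound 3 (1.00 log units; beyond the scatter). Among the compounds shown here, this is the first single-change reading, and it shows that inhibition responds to the group at this place. The change swaps a six-membered aromatic ring with 1 hetero atom for a five-membered one and also brings in a hydrogen-bond donor, and no evidence bears on the cause of the step.

Which of these differences matters remains open. Also open, on these data alone, is how an amine or a carboxylic acid carried on the 1H-indol-6-yl group would read here.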